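The source may report more compounds than this note shows. Statements on the series, on what has been measured and on what is new or still open speak of the compounds shown alone.

Three compounds share one core and differ only in the ring attached to the amide carbonyl carbon. Compound 1 `COc1ccccc1C(=O)Nc1cccc(-c2oc3cc(-c4ccc(F)cc4)ccc3c(=O)c2O)c1` carries a 2-methoxyphenyl there; in a functional assay on HCC1937 cells (Homo sapiens) for antiproliferative activity, read by CCK-8 assay, with a stated time of 72 h (a lower number here means a stronger inhibitor, a higher number a weaker inhibitor), compound 1 gives 9050 nM. Compound 2 `COc1cc(OC)cc(C(=O)Nc2cccc(-c3oc4cc(-c5ccc(F)cc5)ccc4c(=O)c3O)c2)c1` carries a 3,5-dimethoxyphenyl, and in this assay compound 2 gives 6250 nM. Compound 3 `Cc1cc(C)cc(C(=O)Nc2cccc(-c3oc4cc(-c5ccc(F)cc5)ccc4c(=O)c3O)c2)c1` carries a 3,5-dimethylphenyl, and in this assay compound 3 gives 4860 nM. Compound 3 has the lowest of the three numbers, yet every step leading to it stays within the scatter: a 1.9-fold lower number from compound 1 to compound 3 (0.27 log units; within the scatter) and a 1.3-fold lower number from compound 2 to compound 3 (0.11 log units; within the scatter), as does a 1.4-fold lower number from compound 1 to compound 2 (0.16 log units; within the scatter). Across these three compounds the exchange of one ring for another on the carbonyl carbon has not moved the number in a way that can be told from repeat measurement.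

Compound 4 `O=C(Nc1cccc(-c2oc3cc(-c4ccc(F)cc4)ccc3c(=O)c2O)c1)c1ccc(Cl)nc1` has not yet been measured. It differs from compound 3 in one place: 6-chloropyridin-3-yl in place of 3,5-dimethylphenyl on a carbonyl carbon. The three measured steps all swap the ring on this same carbonyl carbon, and none of them moved the number beyond the scatter. On that basis the change to compound 4 is expected to bring no step beyond the scatter in this assay, in either direction. The estimated step is a 1.1-fold higher number from compound 3 to compound 4 (0.05 log units; within the scatter). For compound 4 in this assay the estimate is 5500 nM, with a range from 2200 nM to 14000 nM.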

Compound 4, half-maximal inhibitory concentration: 7550 nM
Estimate against measurement, compound 4: 1.4-fold (0.14 log units) below; the measured number falls inside the stated range.
By their numbers in this assay, from the lowest: compounds 3, 2, 4 and 1 (each within the scatter of the next).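

Setting a ring with a hetero atom, the 6-chloropyridin-3-yl, on the carbonyl carbon gives a 1.6-fold higher number from compound 3 to compound 4 (0.19 log units; within the scatter) and a 1.2-fold higher number from compound 2 to compound 4 (0.08 log units; within the scatter) and a 1.2-fold lower number from compound 1 to compound 4 (0.08 log units; within the scatter) in this assay, and none of these steps can be told apart from repeat measurement. The earlier compounds shown here showed this only for rings of carbon alone, so this place on the amide has now taken a ring nitrogen, a chlorine and a hydrogen-bond acceptor without any separation from those rings, and the four compounds cannot be ranked against one another. The data offer no measurement that could explain why these numbers sit where they do.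

On these data alone, all four groups here are six-membered aromatic rings, so it stays open whether anything of another shape on this carbonyl carbon would give a step beyond the scatter, such as a saturated piperidine ring, a longer alkyl chain or a ring carrying a carboxylic acid. As far as these compounds go, it also stays open whether the same ring swaps would give steps of a similar size if the rest of the shared core were changed.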